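This account rests on a few compounds, and the source may have more. Where it says the series, first, only, none or still open, it means among the compounds named here.

Measured in a functional assay on A549 cells (Homo sapiens) for cytotoxicity, read by MTT assay, with a stated time of 48 h; on this read-out lower numbers stand for stronger inhibition and higher numbers for weaker inhibition:

compound 1 `COc1cc(C(=O)C2Sc3nnc(-c4cc(OC)c(OC)c(OC)c4)n3NC2c2ccco2)cc(OC)c1OC`: 48300 nM
compound 2 `COc1cc(-c2nnc3n2NC(c2ccco2)C(C(=O)c2ccccc2F)S3)cc(OC)c1OC`: 78700 nM
compound 3 `COc1cc(-c2nnc3n2NC(c2ccco2)C(C(=O)C2CC2)S3)cc(OC)c1OC`: a limit, > 100000 nM

Compound 2 gives the highest of the two numbers; its nearest neighbour is compound 1, with a 1.6-fold higher number from compound 1 to compound 2 (0.21 log units; within the scatter). Compound 3 sits at a limit of this assay, (the limit of > 100000 nM in this assay, at which 1 of the 3 values shown sits), so that an at least 1.2-fold higher number from compound 2 to compound 3 (0.10 log units; that floor lies within the scatter) and an at least 2.0-fold higher number from compound 1 to compound 3 (0.31 log units; beyond the scatter) are known only as floors.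

Compound 4 `COc1cc(-c2nnc3n2NC(c2ccco2)C(C(=O)c2cccc(Br)c2)S3)cc(OC)c1OC` is not yet measured; it differs from compound 2 in one place: 3-bromophenyl in place of 2-fluorophenyl on a carbonyl carbon. For the measured compounds named here, the one step that exchanges one aryl group for another on this carbonyl carbon, a 1.6-fold higher number from compound 1 to compound 2 (0.21 log units; within the scatter), stayed within the scatter, while the cyclopropyl step reached only a limit. No step beyond the scatter is therefore expected in this assay; compound 4 is estimated at 80000 nM (40000 nM to 160000 nM), meaning an expected 1.0-fold higher number from compound 2 to compound 4 (0.01 log units; within the scatter).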

Compound 4, half-maximal inhibitory concentration: 36900 nM
Beside the measured number, compound 4's estimate is 2.2-fold (0.34 log units) above it; measured number outside the range, below it.
By their numbers in this assay, from the lowest: compounds 4, 1 and 2 (each within the scatter of the next, the first and the last beyond it). At a limit, above all of these: compound 3.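

In this assay, exchanging one aryl group for another on this carbonyl carbon now moves the number beyond the scatter, with a 2.1-fold lower number from compound 2 to compound 4 (0.33 log units; beyond the scatter). Cyclopropyl and 3-bromophenyl also separate, with an at least 2.7-fold lower number from compound 3 to compound 4 (0.43 log units; beyond the scatter), whereas 3-bromophenyl and 3,4,5-trimethoxyphenyl do not, with a 1.3-fold lower number from compound 1 to compound 4 (0.12 log units; within the scatter). The cyclopropyl step is only a floor, and compound 3 stands at a limit: the limit of > 100000 nM in this assay, at which 1 of the 4 values shown sits.

The compounds shown do not separate the bromine itself from its place on the ring. Going by these compounds, how an aminomethyl or carboxylic acid group on this aryl ring, or a longer alkyl chain in place of the ring, would read also remains open.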